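A Move from 2,6-Dichlorophenyl to 2,4-Dichlorophenyl

The source may hold more compounds than are shown below. What is called first, only, known or untested is meant among the compounds shown, and "the series" means these compounds.

Of the compounds shown here, three sharing one core have been tested in a functional assay on MDA-MB-436 cells (Homo sapiens) for antiproliferative activity, read by MTT assay, with a stated time of 24 h; a higher number here means a weaker inhibitor, a lower number a stronger inhibitor: compound 1 (`O=C(O)CC(NC(=O)c1cccc(Br)c1)c1ccc(Cl)cc1Cl`), compound 2 (`COc1ccccc1C(=O)NC(CC(=O)O)c1ccc(Cl)cc1Cl`) and compound 3 (`O=C(O)CC(NC(=O)c1c(Cl)cccc1Cl)c1ccc(Cl)cc1Cl`). Compound 1 gives > 100000 nM as a limit and not a number. Compound 2 gives > 100000 nM as a limit too. Compound 3 gives > 100000 nM as a limit as well, so it has no number of its own. Together they stand at the limit of > 100000 nM in this assay, at which 3 of the 3 values shown sit, and nothing finer.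

Compound 4 (`O=C(O)CC(NC(=O)c1ccc(Cl)cc1Cl)c1ccc(Cl)cc1Cl`) carries 2,4-dichlorophenyl in place of 2,6-dichlorophenyl on a carbonyl carbon. Three measured changes at that same place bear on it: a step that the two limits leave unreadable from compound 2 to compound 3 and a step that the two limits leave unreadable from compound 1 to compound 3 and also a step that the two limits leave unreadable from compound 1 to compound 2 as the third. None has a readable size. No step beyond the scatter is therefore expected in this assay because the limit of > 100000 nM in this assay, at which 3 of the 3 values shown sit, offers no size or direction to carry over. The expected change is a number no higher from compound 3 to compound 4 (the limit leaves the size open) in this estimate. For compound 4 the estimated half-maximal inhibitory concentration is 100000 nM with an expected range from 30000 nM to 200000 nM and a reading that may well be only a limit again.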

Compound 4, half-maximal inhibitory concentration: 57300 nM
Beside the measured number, compound 4's estimate is 1.7-fold (0.24 log units) above it, and the stated range covers the measured number.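

In this assay, going by these compounds alone, compound 4 is the only one of the four compounds with a number rather than a limit, and a rearrangement of the same atoms at this place on the carbonyl carbon is enough to produce it, giving an at least 1.7-fold lower number from compound 3 to compound 4 (0.24 log units; that floor lies within the scatter). Measured against the other two groups at this place, the change gives an at least 1.7-fold lower number from compound 2 to compound 4 (0.24 log units; that floor lies within the scatter) and an at least 1.7-fold lower number from compound 1 to compound 4 (0.24 log units; that floor lies within the scatter). As far as these compounds go, all three steps are only floors, the steps among compound 1, compound 2 and compound 3 cannot be read, and the true size of each new step stays open because the comparison rests on a limit: the limit of > 100000 nM in this assay, at which 3 of the 4 values shown sit.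

The compounds shown leave open whether a number also appears with 2,4-dibromophenyl or 2,4-difluorophenyl at this place. They also leave open what a methyl ester in place of the carboxylic acid would do.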